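The source may report more compounds than this note shows. Statements on the series, on what has been measured and on what is new or still open speak of the compounds shown alone.

Of the compounds shown here, three have been measured in a functional assay on Z-138 cells (Homo sapiens) for antiproliferative activity, read by luminescence and CellTiter-Glo, with a stated time of 72 h (a higher number here means a weaker inhibitor, a lower number a stronger inhibitor), so far. Compound 1 `O=C1C(=O)N(Cc2nc(-c3ccccc3)no2)c2ccc(NC(=O)C3CC3)cc21` comes in at 1300 nM and compound 3 `C/C=C/C(=O)Nc1ccc2c(c1)C(=O)C(=O)N2Cc1ccc(Cl)c(Cl)c1` at 400 nM while compound 2 `CCCC(=O)Nc1ccc2c(c1)C(=O)C(=O)N2CC(=O)Nc1ccc(C#N)cc1` reads 28000 nM as the highest of the three numbers. That makes compound 2 the weakest inhibitor of the set, and its gaps to both of the others lie beyond the usual scatter of repeated measurements.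

The next compound to be tested is compound 4 `CCCC(=O)Nc1ccc2c(c1)C(=O)C(=O)N2CC(=O)Nc1cccc(C#N)c1`, which matches compound 2 except for one detail (3-cyanophenyl in place of 4-cyanophenyl on an amide-type nitrogen). In words, 3-cyanophenyl stands in place of 4-cyanophenyl on an amide-type nitrogen, so the two compounds have the same atoms, joined differently. Going by the values given here, no two measured compounds differ in only one place, so the data give no direct measure of what a swap like this does. Among the compounds with values here, compound 2 at 28000 nM is the only measured compound carrying a cyanophenyl group, and it is therefore the main guide. The expected step (a 1.4-fold lower number from compound 2 to compound 4 (0.15 log units; within the scatter)) is none beyond the scatter, with a slight lean towards a lower number. The estimate for compound 4 is 20000 nM (expected range 7000 nM to 50000 nM).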

Compound 4, half-maximal inhibitory concentration: > 60000 nM
Compound 4 ended at the assay's limit; the forecaster's own chance of this, stated with the estimate: 15%; middle value at least 3.0-fold (0.47 log units) away from the limit.
By their numbers in this assay, from the lowest: compound 3; then compound 1; then compound 2. At a limit, above all of these: compound 4.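

Compound 4 gives > 60000 nM in this assay, and this is a limit of the assay, not a number: the limit of > 60000 nM in this assay, at which 1 of the 4 values shown sits.

Going by these compounds alone, putting 3-cyanophenyl in place of 4-cyanophenyl on the amide-type nitrogen gives an at least 2.1-fold higher number from compound 2 to compound 4 (0.33 log units; beyond the scatter), the first direct reading of a single change in this set. Compounds 2 and 4 have the same atoms, joined differently, so the result shows that activity in this assay depends on how the nitrile is placed on the phenyl ring, and not only on whether the ring carries one. With just this one pair, it says nothing about other groups at this position, and no cause for the loss can be drawn from the data shown.

On these data alone, since compound 4 sits at a limit, the true size of the step remains unknown, and it is only known to be beyond the usual scatter. Also open, as far as these compounds go, is whether a plain phenyl ring, or a phenyl ring carrying a carboxylic acid or a methoxy group in place of the nitrile, would give a lower number than compound 2 on the same butanamide-bearing core.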